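The compounds below may be only part of what the source reports. "The series", "measured", "known", "first", "only" and "open" are said of these compounds alone.

Measured so far in a functional assay on HCT-116 cells (Homo sapiens) for antiproliferative activity, with a stated time of 72 h; a lower number here means a stronger inhibitor, a higher number a weaker inhibitor: compound 1 `Cc1ccc2[nH]cc(C3=CCN(Cc4ccc(OCC(=O)NO)cc4)CC3)c2c1`, compound 3 `Cc1ccc2[nH]cc(C3=CCN(Cc4ccc(OCC(=O)NO)cc4F)CC3)c2c1` and compound 2 `O=C(COc1ccc(C(=O)NC2CC=C(c3c[nH]c4cccc(F)c34)CC2)cc1)NO`. Compound 1 gives 632 nM and compound 3 gives 1450 nM. Compound 2 reaches only a limit of the assay, > 5000 nM, which is the limit of > 5000 nM in this assay, at which 1 of the 3 values shown sits; it therefore stands at the weak end of the values shown, with no number of its own.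

Compound 4 `Cc1[nH]c2ccccc2c1C1=CCC(NC(=O)c2ccc(OCC(=O)NO)cc2)CC1` follows from compound 2 by 2-methyl-1H-indol-3-yl in place of 4-fluoro-1H-indol-3-yl on a double-bonded ring carbon. Within the data shown here, the single measured step, a 2.3-fold higher number from compound 1 to compound 3 (0.36 log units; beyond the scatter), concerns a fluoro on another ring and does not reproduce this exchange, so no measured pair bears on it directly. For compound 4 a value near the limit of the assay is expected, estimated at 5000 nM with a range of 1500 nM to 15000 nM. The expected step is a number no higher from compound 2 to compound 4 (the limit leaves the size open).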

Compound 4, half-maximal inhibitory concentration: > 5000 nM
Compound 4: a limit, no number (the forecaster's own chance of this, stated with the estimate: 50%); the middle value sits exactly at the limit.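

Among these compounds, compound 2 and compound 4 both stand at a limit, so no step between them can be read: the limit of > 5000 nM in this assay, at which 2 of the 4 values shown sit. Going by these compounds, whether 2-methyl-1H-indol-3-yl in place of 4-fluoro-1H-indol-3-yl changes the antiproliferative activity at all remains open.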